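The source may report more compounds than this note shows. Statements on the series, on what has been measured and on what is new or still open speak of the compounds shown alone.

Of the compounds shown here, two from this series have been tested in a functional assay (aorta) with Rattus norvegicus as the target; on this read-out lower numbers stand for stronger inhibition and higher numbers for weaker inhibition. Compound 1, `C/N=C(/S)C1(c2cccnc2)CCCC/C1=C\CO`, gives 10000 nM in this assay. Compound 2, `C/N=C(/S)[C@@]1(c2cccnc2)CCCC[C@@H]1CCO`, gives 1700 nM in this assay. Of the two numbers on record, that of compound 2 is the lower one, and the gap to compound 1 lies beyond the usual scatter of repeated measurements; since the two structures differ in more than one place, nothing more than this comparison of their values can be drawn from the pair.

Compound 3, `C/N=C(/S)[C@@]1(c2cccnc2)CCCC[C@@H]1CCNC(=O)C(C)C`, has not yet been measured in this assay. It is obtained from compound 2 by a single change: (isopropylcarbonyl)amino in place of hydroxy on a saturated chain carbon, two bonds along the chain from a saturated ring carbon. Within the data shown here, no measured pair in the set shows the effect of such a change, so the expectation rests on compound 2 alone.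

For compound 3, the step of a 1.5-fold higher number from compound 2 to compound 3 (0.17 log units; within the scatter) is expected to stay within the usual scatter, with no clear direction. Compound 3 is accordingly estimated at 2500 nM in this assay, with a range from 600 nM to 10000 nM.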

Compound 3, concentration for 90% inhibition: 300 nM
For compound 3 the middle estimate is 8.3-fold (0.92 log units) above the measured one; measured number outside the range, below it.
By their numbers in this assay, from the lowest: compound 3; then compound 2; then compound 1.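

In this assay the exchange of hydroxy for (isopropylcarbonyl)amino on a saturated chain carbon, two bonds along the chain from a saturated ring carbon, gives a 5.7-fold lower number from compound 2 to compound 3 (0.75 log units; beyond the scatter) and so produces a modest step that lies beyond the scatter. Among these compounds, this is the only single-place comparison in the set, and it shows that this end of the chain tolerates far more than the hydroxy of compound 2: six heavy atoms stand in place of one, and the number falls rather than rises. No measured property or other evidence is at hand to explain the gain, so it remains an observation about this one pair.

The compounds shown leave open which part of the new group carries the step, and a plain amine, an acetyl amide or a cyclohexylcarbonyl amide at the same place would separate the amide link from the isopropyl end. They also leave open whether the chain length matters, which a 3-((isopropylcarbonyl)amino)propyl chain would test, and whether the same amide would act similarly on the unsaturated chain of compound 1.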